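The source may hold more compounds than are shown below. What is called first, only, known or untested is meant among the compounds shown, and "the series" means these compounds.

Compound 2 `COc1ccc(F)cc1CNCCCNc1ccnc2cc(CC(C)C)ccc12` gives 4200 nM in a physicochemical assay for solubility, with a stated time of 18 h, at pH 7.4 (a higher number here means a more soluble compound, a lower number a less soluble compound), level with compound 1 `CCC(CC)c1ccc2c(NCCCNCc3cc(F)ccc3OC)ccnc2c1`, which gives 4200 nM. Among the measured compounds shown here, the single measured step, no change at the digits printed from compound 1 to compound 2 (within the scatter), stayed within the scatter. Compound 3 `COc1ccc(F)cc1CNCCCNc1ccnc2cc(-c3ccccc3)ccc12` differs from compound 2 by phenyl in place of isobutyl on an aromatic carbon. For the measured compounds named here, that earlier step exchanged one alkyl chain for another, whereas the change here brings in a six-membered aromatic ring of carbon only, for which no measured step exists. On that thin basis a modest downward shift in this assay is expected, a 1.7-fold lower number from compound 2 to compound 3 (0.23 log units; within the scatter). The estimate for compound 3 is 2500 nM, with a range from 800 nM to 8000 nM.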

Compound 3, solubility: 32000 nM
Compound 3: middle estimate off by 13-fold (1.11 log units), on the low side, and the stated range ends below it.
By their numbers in this assay, from the lowest: compounds 1 and 2 (each within the scatter of the next); then compound 3.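

Putting phenyl on this aromatic carbon produces a 7.6-fold higher number from compound 2 to compound 3 (0.88 log units; beyond the scatter) in this assay and the same size of change as a 7.6-fold higher number from compound 1 to compound 3 (0.88 log units; beyond the scatter) when pentan-3-yl is the group replaced. The earlier exchange of one alkyl group for another left the number unchanged, so this position can register a change of substituent when an aromatic ring enters. No available evidence bears on why the number rises.

A cyclohexyl group or a pyridine ring on this carbon would show whether the rise follows any ring or this ring alone. On these data alone, how an amine or a carboxylic acid here would compare remains open.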